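Swapping the Basic Side Chain on a Bis-Bromo Sulfonamide

The source may hold more compounds than are shown below. What is called first, only, known or untested is meant among the compounds shown, and "the series" means these compounds.

Measured in a functional assay on BXPC-3 cells (Homo sapiens) for antiproliferative activity, read by MTT assay, with a stated time of 48 h; a higher number here means a weaker inhibitor, a lower number a stronger inhibitor:
compound 1 `CN(C)CCNC(=O)c1nc2cc(N(Cc3ccc(Br)cc3)S(=O)(=O)c3ccc(Br)cc3)ccc2o1`: 13700 nM
compound 2 `CCN(CC)CCNC(=O)c1nc2cc(N(Cc3ccc(Br)cc3)S(=O)(=O)c3ccc(Br)cc3)ccc2o1`: 16300 nM

Within the data shown here, only these two compounds have been measured, and compound 2, at 16300 nM, stands within the scatter of compound 1, its single neighbour. The next compound, compound 3 `CN1CCC(NC(=O)c2nc3cc(N(Cc4ccc(Br)cc4)S(=O)(=O)c4ccc(Br)cc4)ccc3o2)CC1`, carries 1-methylpiperidin-4-yl in place of 2-(diethylamino)ethyl on an amide-type nitrogen. The group that enters has a six-membered non-aromatic ring, and the group that leaves has no ring.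

Among the measured compounds shown here, one measured step bears on this change. It is a 1.2-fold higher number from compound 1 to compound 2 (0.08 log units; within the scatter), and it alters the same side chain at its diethylamino or dimethylamino end. For the measured compounds named here, that step is a weak guide, since it leaves the chain in place and no ringed group has yet been measured. With so little evidence, no step beyond the scatter is expected in this assay, and no direction is favoured with confidence. The estimated step is a 1.1-fold lower number from compound 2 to compound 3 (0.05 log units; within the scatter). For compound 3 the expected value is 14500 nM, with an estimated range of 7000 nM to 30000 nM.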

Compound 3, half-maximal inhibitory concentration: 10200 nM
For compound 3 the middle estimate is 1.4-fold (0.15 log units) above the measured one, within the range that was stated.
By their numbers in this assay, from the lowest: compounds 3, 1 and 2 (each within the scatter of the next).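

In this assay, the change from the open 2-(diethylamino)ethyl chain to the ringed 1-methylpiperidin-4-yl on the amide-type nitrogen gives a 1.6-fold lower number from compound 2 to compound 3 (0.20 log units; within the scatter), and the same ringed group in place of 2-(dimethylamino)ethyl gives a 1.3-fold lower number from compound 1 to compound 3 (0.13 log units; within the scatter). Among these compounds, this is the first sign that this position can carry a six-membered non-aromatic ring as well as an open chain, and neither step leaves the scatter, so compounds 1, 2 and 3 cannot be told apart in this assay. No measurement offered here gives a cause for these small steps.

The compounds shown leave open whether any group on this amide-type nitrogen would move the number beyond the scatter, for example a morpholine ring, a piperidin-4-yl ring with no methyl on its nitrogen, a longer chain between the amide-type nitrogen and the amine, or a chain ending in a carboxylic acid. Going by these compounds, all three compounds also share the same two bromine-bearing rings, so it remains open whether these side chains would stay as closely matched with chlorine in place of bromine.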